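The source may report more compounds than this note shows. Statements on the series, on what has been measured and on what is new or still open speak of the compounds shown alone.

Measured so far in an assay on HEK293 cells for inhibition of Indoleamine 2,3-dioxygenase 1 (Homo sapiens), with a stated time of 30 min; a lower number here means that less compound is needed, a higher number that more compound is needed for the effect:

compound 1 `Brc1ccc2[nH]c(-c3cncn3Cc3ccccc3)cc2c1` gives 11000 nM
compound 2 `c1ccc(Cn2cncc2-c2cc3ccccc3[nH]2)cc1` gives 10800 nM
compound 3 `FC(F)(F)c1ccc(Cn2cncc2-c2cc3cc(Br)ccc3[nH]2)cc1` gives 4590 nM

Compound 1 has the highest number of these three in this assay. Its nearest neighbour is compound 2, and that pair sits a 1.0-fold lower number from compound 1 to compound 2 (0.01 log units; within the scatter), a change that took place on the other ring of the shared core. Compound 3 is further away, the step of a 2.4-fold lower number from compound 1 to compound 3 (0.38 log units; beyond the scatter) arising from a change on the benzyl ring that hangs off the imidazole.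

The new compound 4 `Nc1ccccc1Cn1cncc1-c1cc2cc(Br)ccc2[nH]1` is compound 1 with amino in place of hydrogen on an aromatic carbon, placed on an aromatic carbon of a six-membered aromatic ring of carbon only, ortho to a large group. Among the measured compounds shown here, of the two measured steps, only the one from compound 1 to compound 3 concerns this same benzyl ring, and it was modest. The step to compound 2 touches a different ring and says little here. For the measured compounds named here, no measured pair shows an amino group entering anywhere, so the direction of the change is open, and a small shift, perhaps not beyond the scatter, is the most that can be read from these numbers. Compound 4 is therefore expected to land near compound 1, with an estimated step of a 1.4-fold lower number from compound 1 to compound 4 (0.14 log units; within the scatter), giving an estimate of 8000 nM within a range from 3000 nM to 20000 nM.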

Compound 4, half-maximal effective concentration: 12000 nM
Compound 4: the middle estimate sits 1.5-fold (0.18 log units) below what was measured; measured number inside the range.
By their numbers in this assay, from the lowest: compound 3; then compounds 2, 1 and 4 (each within the scatter of the next).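

In this assay, the change from phenyl to 2-aminophenyl gives a 1.1-fold higher number from compound 1 to compound 4 (0.04 log units; within the scatter), so the numbers for these two compounds cannot be told apart. Among the compounds shown here, this is the first view of an amino group on this ring, and it shows that a group with a hydrogen-bond donor and acceptor can stand on this aromatic carbon, ortho to a large group, without a step beyond the scatter. Nothing available here accounts for this result, so the flat step can only be recorded, not explained.

For the compounds shown here, the only step on this ring that lies beyond the scatter remains a 2.4-fold lower number from compound 1 to compound 3 (0.38 log units; beyond the scatter), and a single amino compound cannot show whether that trifluoromethyl step depends on the group, on where it sits, or on both. The compounds shown leave open whether a hydroxyl group, a carboxylic acid or a longer chain ending in an amine on this same aromatic carbon would also give a number close to that of compound 1, and whether amino would do so elsewhere on the ring.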